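Trimming the Far Aryl Group in a Sulfonamide Series

The compounds below may be only part of what the source reports. "The series", "measured", "known", "first", "only" and "open" are said of these compounds alone.

Two sulfonamides share one core and differ only at the far end of their chain. Compound 1 `O=S(=O)(NCCNCc1cccc2ccccc12)c1cc(C(F)(F)F)cc(C(F)(F)F)c1` and compound 2 `O=S(=O)(NCCCNCc1ccc(Cl)c(C(F)(F)F)c1)c1cc(C(F)(F)F)cc(C(F)(F)F)c1` were tested in a functional assay on BE(2)-C cells (Homo sapiens) for inhibition, read by MTT assay, with a stated time of 72 h; on this read-out lower numbers stand for stronger inhibition of growth and higher numbers for weaker inhibition of growth. In this assay compound 1 gives 19000 nM, while compound 2 gives 8600 nM, the lower of the two numbers, a gap beyond the usual scatter. Compound 3 `O=S(=O)(NCCCNCc1cccc(Cl)c1)c1cc(C(F)(F)F)cc(C(F)(F)F)c1` is not yet measured; it carries 3-chlorophenyl in place of 4-chloro-3-(trifluoromethyl)phenyl on a saturated chain carbon bound to an amine nitrogen. For the measured compounds named here, no measured step of this kind exists here, so only a modest move toward weaker inhibition of growth is expected, and the estimated step is a 1.7-fold higher number from compound 2 to compound 3 (0.24 log units; within the scatter). For compound 3 the expected value in this assay is 15000 nM, within a range from 6000 nM to 40000 nM.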

Compound 3, concentration for 50% growth inhibition: 6900 nM
Compound 3: middle estimate off by 2.2-fold (0.34 log units), on the high side; measured number inside the range.
By their numbers in this assay, from the lowest: compounds 3 and 2 (each within the scatter of the next); then compound 1.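

In this assay the swap of 4-chloro-3-(trifluoromethyl)phenyl for 3-chlorophenyl gives a 1.2-fold lower number from compound 2 to compound 3 (0.10 log units; within the scatter) and so stays inside the scatter. On a saturated chain carbon bound to an amine nitrogen, the smaller aryl group without trifluoromethyl therefore reads the same as the larger one, which the earlier pair could not show. Whether an unsubstituted phenyl ring or a 3-(trifluoromethyl)phenyl group would also read the same remains open, and nothing measured here offers an explanation for this result.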